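A Hydroxy Group in Place of Hydrogen: Expected Inhibition

The source may report more compounds than this note shows. Statements on the series, on what has been measured and on what is new or still open speak of the compounds shown alone.

Measured so far:
Compound 1 `COc1ccc(/C=N/n2c(CSc3nnc(-c4ccncc4)o3)nc3ccccc3c2=O)cc1`: 20%
Compound 2 `O=c1c2ccccc2nc(CSc2nnc(-c3ccncc3)o2)n1/N=C/c1ccccc1`: 16.3%

In a functional assay on the whole organism (strain Charles-Foster albino) for inhibition, with Rattus norvegicus as the target, read by paw edema, at a dose of 50 mg/kg by the oral route (a higher number here means more inhibition at the dose given (going by the name of the read-out), a lower number less inhibition), compound 2 gives 16.3%, the lower of the two numbers, though its gap to compound 1 is within the scatter: a number 3.7 percentage points lower from compound 1 to compound 2 (within the scatter). Compound 3 `O=c1c2ccccc2nc(CSc2nnc(-c3ccncc3)o2)n1/N=C/c1ccc(O)cc1` is not yet measured. It differs from compound 2 in one place: hydroxy in place of hydrogen on an aromatic carbon. Among the measured compounds shown here, no measured step carries this exact change. For the measured compounds named here, the only step available, a number 3.7 percentage points lower from compound 1 to compound 2 (within the scatter), swaps a small group on the same ring for hydrogen and stays within the scatter, which suggests that small changes at this position do not move the read-out far. The step for compound 3 is therefore expected to be small, a number 3.7 percentage points higher from compound 2 to compound 3 (within the scatter), with no direction beyond the scatter. Compound 3 is estimated at 20% in this assay, with a range from 8% to 32%.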

Compound 3, a percentage reported as inhibition, in the whole organism at one dose (the size of the read-out at that dose, not a potency): 18.2%
For compound 3 the middle estimate is 1.8 percentage points above the measured one; the range from low to high includes it.
By their numbers in this assay, from the lowest: compounds 2, 3 and 1 (each within the scatter of the next).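

In this assay the change from phenyl to 4-hydroxyphenyl gives a number 1.9 percentage points higher from compound 2 to compound 3 (within the scatter) and so adds a second group, after methoxy, that can stand para to a large group without a step beyond the scatter. Taking the methyl off that oxygen gives a number 1.8 percentage points lower from compound 1 to compound 3 (within the scatter) and so shows that hydrogen, hydroxy and methoxy at this place cannot be told apart by this read-out at this dose. Nothing available on these compounds accounts for this result.

The compounds shown leave open whether an amine, a carboxylic acid or a longer chain such as butoxy at this same place would give a step beyond the scatter. They also leave open whether hydroxy or methoxy on another carbon of this ring would behave as they do here.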